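Swapping 2,6-dimethylphenyl for 2,4-dimethylphenyl on the shared core

The source may hold more compounds than are shown below. What is called first, only, known or untested is meant among the compounds shown, and "the series" means these compounds.

Going by the values given here, in a physicochemical assay for solubility, in phosphate buffer, measured as kinetic solubility, at pH 7.4 (on this read-out lower numbers stand for lower solubility and higher numbers for higher solubility), compound 3 `Cc1cccc(C)c1-c1nc(CN2CCC(C(=O)NCCCN3C[C@H](C)C[C@H](C)C3)CC2)c(C)o1` gives 55.9 ug/mL, the only true number among the compounds measured so far. Compound 1 `Cc1oc(-c2ccccc2Cl)nc1CN1CCC(C(=O)NCCCN2C[C@H](C)C[C@H](C)C2)CC1` reports > 72 ug/mL, which is a limit of the assay. Compound 2 `Cc1cccc(F)c1-c1nc(CN2CCC(C(=O)NCCCN3C[C@H](C)C[C@H](C)C3)CC2)c(C)o1` reports > 72 ug/mL, which is also a limit.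

Compound 4 `Cc1ccc(-c2nc(CN3CCC(C(=O)NCCCN4C[C@H](C)C[C@H](C)C4)CC3)c(C)o2)c(C)c1` has not yet been measured. It carries 2,4-dimethylphenyl in place of 2,6-dimethylphenyl on an aromatic carbon of the shared core, and the two have the same atoms, joined differently: 2,4-dimethylphenyl in place of 2,6-dimethylphenyl on an aromatic carbon.

Two measured steps alter the same substituent: an at least 1.2-fold lower number from compound 1 to compound 3 (0.10 log units; that floor lies within the scatter), and an at least 1.2-fold lower number from compound 2 to compound 3 (0.10 log units; that floor lies within the scatter). Both are floors set by a limit and lie within the scatter, while a step that the two limits leave unreadable from compound 1 to compound 2 cannot be sized. Among the compounds with values here, none of the measured steps moves a methyl group around this ring, so the evidence is indirect, and no shift beyond the scatter is anticipated in this assay. The expected change is small: a 1.1-fold higher number from compound 3 to compound 4 (0.03 log units; within the scatter). For compound 4 the estimated value is 60 ug/mL, with an expected range from 30 ug/mL to 90 ug/mL.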

Compound 4, solubility: > 71 ug/mL
Compound 4 gave a limit, no number; the forecaster's own chance of this, stated with the estimate: 30%; at least 1.1-fold (0.07 log units) between middle value and limit.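

The earlier steps shown here all replaced a halogen or a methyl group, whereas this one only moves a methyl group around the phenyl ring, and in this assay compound 4 gives > 71 ug/mL, which is a limit of the assay and not a number. Moving that methyl group gives an at least 1.2-fold higher number from compound 3 to compound 4 (0.10 log units; that floor lies within the scatter), so this change can be given only as a floor, and nothing printed sets it beyond the scatter. The steps to compound 4 from compound 1 and from compound 2 join two limits and cannot be read.

On these data alone, how far compound 4 truly stands from compound 3 remains open, and the limits leave the compounds that carry them unranked. As far as these compounds go, it is also open how an amine or a carboxylic acid in place of one methyl group on the 2,4-dimethylphenyl would read out in this assay.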